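Methoxy to ethoxy on a weakly antiproliferative core

The source may hold more compounds than are shown below. What is called first, only, known or untested is meant among the compounds shown, and "the series" means these compounds.

Three measured compounds share one core and differ only in the aryl group on an aromatic nitrogen: compound 1 `Cc1ccccc1-n1nncc1CN1C(=O)C2(C(C#N)=C(N)Oc3c2c2nc4ccccc4nc2c2ccccc32)c2ccccc21`, compound 2 `Cc1cccc(-n2nncc2CN2C(=O)C3(C(C#N)=C(N)Oc4c3c3nc5ccccc5nc3c3ccccc43)c3ccccc32)c1` and compound 3 `COc1ccccc1-n1nncc1CN1C(=O)C2(C(C#N)=C(N)Oc3c2c2nc4ccccc4nc2c2ccccc32)c2ccccc21`. In a functional assay on A549 cells (Homo sapiens) for antiproliferative activity, read by MTT assay, with a stated time of 48 h (a lower number here means a stronger inhibitor, a higher number a weaker inhibitor), compound 1 gives > 50000 nM, which is a limit of the assay rather than a number. Compound 2 gives 39600 nM in this assay. Compound 3 gives > 50000 nM, again a limit. The step of an at least 1.2-fold lower number from compound 1 to compound 2 (0.10 log units; that floor lies within the scatter) and the step of an at least 1.2-fold higher number from compound 2 to compound 3 (0.10 log units; that floor lies within the scatter) are both floored, and the step that the two limits leave unreadable from compound 1 to compound 3 cannot be read at all; (the limit of > 50000 nM in this assay, at which 2 of the 3 values shown sit). Going by the values given here, compound 3 therefore stands at the limit, with compound 2 holding the only numbered value.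

Compound 4 `CCOc1ccccc1-n1nncc1CN1C(=O)C2(C(C#N)=C(N)Oc3c2c2nc4ccccc4nc2c2ccccc32)c2ccccc21` differs from compound 3 by methyl in place of hydrogen on a saturated chain carbon bound to an oxygen on an aromatic ring. Among the compounds with values here, none of the measured steps touches this chain; they concern the methyl position or methoxy for methyl and were all small or unreadable, so no shift beyond the scatter is expected in this assay. Compound 4 is expected near 60000 nM, between 20000 nM and 200000 nM, most likely reported as a limit. The expected step that the limit leaves unreadable from compound 3 to compound 4 is estimated to be negligible.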

Compound 4, half-maximal inhibitory concentration: > 50000 nM
Compound 4 was reported as a limit; the forecaster's own chance of this, stated with the estimate: 80%; the middle value lies beyond the limit too.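

With methyl in place of hydrogen on a saturated chain carbon bound to an oxygen on an aromatic ring, compound 4 gives > 50000 nM in this assay, which is a limit and not a number. Going by these compounds alone, the steps to compound 4 from compound 3 and from compound 1 cannot be read, and the only readable step is an at least 1.2-fold higher number from compound 2 to compound 4 (0.10 log units; that floor lies within the scatter). Methoxy to ethoxy therefore gives the series no second numbered value, and the limit now holds most of the compounds: the limit of > 50000 nM in this assay, at which 3 of the 4 values shown sit.

From the compounds shown here alone, whether any change at this chain can bring a compound clear of the limit stays open, as does the true size of the methoxy to ethoxy step. A longer chain such as propoxy, or an amine or a carboxylic acid at the end of the chain, would bear on the first question.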